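Plasma protein binding: from compound 2 to compound 3

This account rests on a few compounds, and the source may have more. Where it says the series, first, only, none or still open, it means among the compounds named here.

Compounds measured so far:
Compound 1, `Cc1cc(Nc2ccc(C(F)(F)F)cc2)n2nc(C3CC3)nc2n1`, gives 92.8% in an ADME assay on a cell-free system (plasma, Homo sapiens) for protein binding.
Compound 2, `CCOc1nc2nc(C)cc(Nc3ccc(C(F)(F)F)cc3)n2n1`, gives 92.4% in this assay.

Compound 2 stands with the highest of the two unbound fractions measured so far, yet the difference to compound 1 is small: a 1.1-fold higher unbound fraction from compound 1 to compound 2 (0.02 log units; within the scatter). Both compounds therefore sit at nearly the same degree of binding, and swapping the cyclopropyl of compound 1 for the ethoxy of compound 2 made no difference that the assay can resolve.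

Compound 3, `CSc1nc2nc(C)cc(Nc3ccc(C(F)(F)F)cc3)n2n1`, has not yet been measured. It differs from compound 2 in one place: methylsulfanyl in place of ethoxy on an aromatic carbon.

Among the measured compounds shown here, only one measured step is available, a 1.1-fold higher unbound fraction from compound 1 to compound 2 (0.02 log units; within the scatter), and it changed a different group at the same carbon without moving the value. For the measured compounds named here, no step with methylsulfanyl itself has been measured. The expectation is therefore that compound 3 stays close to compound 2, with the estimated step a 1.2-fold lower unbound fraction from compound 2 to compound 3 (0.07 log units; within the scatter), which is within the scatter. For compound 3 in this assay the estimated binding is 93.5%, with a likely range from 89% to 97%.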

Compound 3, plasma protein binding in the plasma assay: 91.8%
The estimate for compound 3 lay 1.3-fold (0.10 log units) (unbound fraction) below the measured number, within the range that was stated.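

In the plasma assay a third group on this aromatic carbon, between two ring nitrogen atoms, still gives no difference that can be resolved (a 1.1-fold higher unbound fraction from compound 2 to compound 3 (0.03 log units; within the scatter)) and the same holds against the cyclopropyl compound (a 1.1-fold higher unbound fraction from compound 1 to compound 3 (0.06 log units; within the scatter)), so cyclopropyl, ethoxy and methylsulfanyl cannot be told apart on this read-out, even though methylsulfanyl carries a sulfur where ethoxy carries an oxygen. The swap also leaves the second read-out within the scatter: in a physicochemical assay for lipophilicity, at pH 7.4 (on this read-out higher numbers stand for higher lipophilicity and lower numbers for lower lipophilicity), compound 2 gives 3.1 and compound 3 gives 3.2 (a number 0.10 log units higher from compound 2 to compound 3 (within the scatter)), so these two compounds match on both measures. No measured finding is available that would explain why binding holds steady across these groups.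

Going by these compounds, what remains open is whether any group at this carbon can move binding beyond the scatter, for instance an amine, a carboxylic acid or a chain longer than ethoxy. The trifluoromethyl group and the methyl group on the core are the same in all three compounds, so these results say nothing about how either one contributes to binding.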